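Moving the Fluorine on a Small Ring Core

This account rests on a few compounds, and the source may have more. Where it says the series, first, only, none or still open, it means among the compounds named here.

This account follows a set of compounds tested in an ADME assay on cells (Epithelial cell, Homo sapiens) for antiproliferative activity, read by MTT assay, with a stated time of 48 h (on this read-out higher numbers stand for weaker inhibition and lower numbers for stronger inhibition), and asks what a shift of a single fluorine might do. Compound 1, with the structure `CCOC(=O)/C(=C/c1ccccc1)CN1C(=O)[C@@H](OC)[C@H]1c1cccc([N+](=O)[O-])c1`, is reported in this assay only as "not toxic" (no number reported), without a number. Compound 2, with the structure `CO[C@@H]1C(=O)N(C/C(C#N)=C/c2ccccc2)[C@@H]1c1ccc(Cl)cc1Cl`, reaches only a limit of the assay in this assay, given as > 100000 nM; this is the limit described by the limit of > 100000 nM in this assay, at which 1 of the 3 values shown sits. Among the compounds with values here, compound 3, with the structure `COC(=O)/C(=C/c1ccccc1)CN1C(=O)[C@@H](OC)[C@H]1c1cccc(F)c1`, gives 38500 nM in this assay, and that is the only number among the three entries.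

Compound 4, with the structure `COC(=O)/C(=C/c1ccccc1)CN1C(=O)[C@@H](OC)[C@H]1c1ccc(F)cc1`, is the unmeasured partner of compound 3. The two share the same atoms joined differently, and the change is 4-fluorophenyl in place of 3-fluorophenyl on a saturated ring carbon. Within the data shown here, no step between measured compounds is available to set a scale for such a move. The expectation is that the step from compound 3 to compound 4 stays within the usual scatter, a 1.0-fold higher number from compound 3 to compound 4 (0.02 log units; within the scatter), in no clear direction. Compound 4 is therefore expected to give about 40000 nM in this assay, within a range from 15000 nM to 100000 nM.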

Compound 4, half-maximal inhibitory concentration: 27900 nM
Compound 4: the middle estimate sits 1.4-fold (0.16 log units) above what was measured; low and high end bracket the measured number.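

In this assay, within the data shown here, the shift of the fluorine gives a 1.4-fold lower number from compound 3 to compound 4 (0.14 log units; within the scatter), and this is the first pair in the account that differs in one place only. It shows that, on this saturated ring carbon of the four-membered ring, 4-fluorophenyl and 3-fluorophenyl cannot be told apart by this read-out, so the change sets a first scale for this position that the earlier entries could not give. Nothing in the data shown offers a reason for so small a step.

The compounds shown leave open whether a group of another kind on this phenyl ring, such as an amine or a carboxylic acid, would carry the number beyond the scatter, or whether a longer chain in place of the methoxy group on the neighbouring ring atom would do so. Also open is what a nitrile in place of the methyl ester would do with the fluorophenyl group kept as it is, a single change that none of the pairs shown isolates.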